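The source may report more compounds than this note shows. Statements on the series, on what has been measured and on what is new or still open speak of the compounds shown alone.

Within the data shown here, compound 2 `C/C(=N/c1nnc(CCCc2c[nH]c3ccccc23)s1)c1cc2cc(Br)ccc2oc1=O` gives the lowest of the two numbers so far in a functional assay on MCF7 cells (Homo sapiens) for inhibition, read by MTT assay, with a stated time of 48 h (on this read-out lower numbers stand for stronger inhibition and higher numbers for weaker inhibition), at 8010 nM. Among the measured compounds shown here, the only other measured compound, compound 1 `C/C(=N/c1nnc(Cc2c[nH]c3ccccc23)s1)c1cc2cc(Br)ccc2oc1=O`, gives 82100 nM in this assay, a gap beyond the usual scatter. Compound 3 `C/C(=N/c1nnc(CCc2c[nH]c3ccccc23)s1)c1cc2cc(Br)ccc2oc1=O` differs from compound 2 in one place: 1H-indol-3-yl in place of (1H-indol-3-yl)methyl on a saturated chain carbon, two bonds along the chain from an aromatic carbon. For the measured compounds named here, no step between measured compounds shows what this change does; the two values only show that the shorter chain of compound 1 goes with the higher number. The step from compound 2 to compound 3 is therefore expected to raise the number beyond the scatter, by about a 3.1-fold higher number from compound 2 to compound 3 (0.49 log units; beyond the scatter). Compound 3 is estimated at 25000 nM, between 8000 nM and 80000 nM.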

Compound 3, half-maximal inhibitory concentration: 36100 nM
Estimate against measurement, compound 3: 1.4-fold (0.16 log units) below; the range from low to high includes it.
By their numbers in this assay, from the lowest: compound 2; then compound 3; then compound 1.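

In this assay, (1H-indol-3-yl)methyl in place of 1H-indol-3-yl gives a 2.3-fold lower number from compound 1 to compound 3 (0.36 log units; beyond the scatter) at this chain position, and the reverse change on the longer chain gives a 4.5-fold higher number from compound 2 to compound 3 (0.65 log units; beyond the scatter) in the same read-out. The number therefore falls in order as the chain grows from compound 1 through compound 3 to compound 2, and none of the three goes against this order. No evidence at hand accounts for this trend. As far as these compounds go, whether a longer chain than that of compound 2 lowers the number further remains open, as does the effect of an amine on this chain.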